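From Phenyl to Pyrazinyl: An Expected Small Step

The compounds below may be only part of what the source reports. "The series", "measured", "known", "first", "only" and "open" are said of these compounds alone.

Of the compounds shown here, three have so far been tested in a functional assay on Bel-7402 cells (Homo sapiens) for cytotoxicity, read by resazurin assay, with a stated time of 72 h; a higher number here means a weaker inhibitor, a lower number a stronger inhibitor. Compound 1 `O=C(CCSC(=S)NCc1cccnc1)NCc1ccccc1` gives only a limit in this assay, > 100000 nM. That reading is the limit of > 100000 nM in this assay, at which 1 of the 3 values shown sits, so no number is known for compound 1. Compound 2 `S=C(NCc1cccnc1)SCCn1nc2ccccc2n1` gives 2660 nM in this assay. Compound 3 `S=C(NCc1cccnc1)SCCc1nnc(-c2ccccc2)o1` gives 1230 nM in this assay, which is the lowest of the two numbers; the nearest is compound 2, whose number is higher by a margin beyond the usual scatter.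

Compound 4 `S=C(NCc1cccnc1)SCCc1nnc(-c2cnccn2)o1` differs from compound 3 in a single place: pyrazin-2-yl in place of phenyl on an aromatic carbon. Among the compounds with values here, no pair of measured compounds differs in this way, so the size of the step cannot be read from the numbers. A small step is expected, either toward a somewhat higher number or none beyond the scatter, amounting to an estimated 1.5-fold higher number from compound 3 to compound 4 (0.17 log units; within the scatter). Compound 4 is accordingly expected to give about 1800 nM in this assay, with an estimated range from 600 nM to 5500 nM.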

Compound 4, half-maximal inhibitory concentration: 1430 nM
Compound 4: the middle estimate sits 1.3-fold (0.10 log units) above what was measured, and the stated range covers the measured number.
By their numbers in this assay, from the lowest: compounds 3, 4 and 2 (each within the scatter of the next, the first and the last beyond it). At a limit, above all of these: compound 1.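

Putting pyrazin-2-yl in place of phenyl adds two ring nitrogens and two hydrogen-bond acceptors, yet the result is a 1.2-fold higher number from compound 3 to compound 4 (0.07 log units; within the scatter). Within the data shown here, this is the first reading of a change at this place on the five-membered aromatic ring, and it shows that in this assay the two six-membered aromatic rings cannot be told apart, so this one swap of ring atoms leaves the reading unmoved. The compounds shown offer no measured basis for explaining this outcome.

On these data alone, both groups read at this place are six-membered aromatic rings, so it remains open how something quite different there, such as a methyl group, a carboxylic acid or an open-chain amine, would read. As far as these compounds go, it is also open whether a phenyl carrying an amine would stay level with these two compounds or move beyond the scatter.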